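This account rests on a few compounds, and the source may have more. Where it says the series, first, only, none or still open, it means among the compounds named here.

Compound 1 `COc1cc2c(Oc3ccc(NC(=O)c4nn(-c5ccccc5Br)c(=O)c5ccccc45)cc3F)ccnc2cc1OCCCN1CCN(C)CC1` gives 400 nM in a functional assay on MKN-45 cells (Homo sapiens) for cytotoxicity, read by MTT assay, with a stated time of 72 h; on this read-out lower numbers stand for stronger inhibition and higher numbers for weaker inhibition. Compound 2 `COc1cc2c(Oc3ccc(NC(=O)c4nn(-c5ccc(F)cc5)c(=O)c5ccccc45)cc3F)ccnc2cc1OCCCN1CCC(C)CC1` gives 130 nM in this assay.

On these two numbers compound 2 stands lowest; compound 1, which differs from it in two places, gives a higher number in this assay, a gap beyond the usual scatter. Compound 3 `COc1cc2c(Oc3ccc(NC(=O)c4nn(-c5ccccc5Br)c(=O)c5ccccc45)cc3F)ccnc2cc1OCCCN1CCC(C)CC1` carries the change (2-bromophenyl in place of 4-fluorophenyl on an aromatic nitrogen). For the measured compounds named here, no measured pair shows this change alone. Compound 3 is therefore expected to stay close to compound 2, with a step of a 1.9-fold higher number from compound 2 to compound 3 (0.28 log units; within the scatter) that is small and, if anything, toward a higher number. The estimate for compound 3 in this assay is 250 nM, within 100 nM to 700 nM.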

Compound 3, half-maximal inhibitory concentration: 510 nM
Beside the measured number, compound 3's estimate is 2.0-fold (0.31 log units) below it; measured number inside the range.
By their numbers in this assay, from the lowest: compound 2; then compounds 1 and 3 (each within the scatter of the next).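

In this assay, 2-bromophenyl in place of 4-fluorophenyl on the aromatic nitrogen gives a 3.9-fold higher number from compound 2 to compound 3 (0.59 log units; beyond the scatter) in a clean single-place comparison, so this position does respond to the aryl group. With 2-bromophenyl held, 4-methylpiperidin-1-yl in place of 4-methylpiperazin-1-yl gives a 1.3-fold higher number from compound 1 to compound 3 (0.11 log units; within the scatter) and stays within the scatter. Nothing available explains either result.

Whether the step follows the bromine or its place on the ring stays open, since the compounds shown include neither 4-bromophenyl nor 2-fluorophenyl on this nitrogen. Also open, going by these compounds, is whether the chain-end comparison holds with 4-fluorophenyl in place.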